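The source may hold more compounds than are shown below. What is called first, only, known or untested is meant among the compounds shown, and "the series" means these compounds.

Compound 1 `NC(=O)c1c(NC(=O)c2ccccc2Cl)sc2c1CCN(Cc1ccccc1Cl)C2` gives 27500 nM in a functional assay on HeLa cells (Homo sapiens) for antiproliferative activity, with a stated time of 24 h; a lower number here means a stronger inhibitor, a higher number a weaker inhibitor. Compound 2 `NC(=O)c1c(NC(=O)c2ccccc2Cl)sc2c1CCN(C(=O)Nc1ccccc1Cl)C2` gives 45400 nM in this assay, the highest of the two numbers, though the step of a 1.7-fold higher number from compound 1 to compound 2 (0.22 log units; within the scatter) stays within the scatter. The move to compound 3 `NC(=O)c1c(NC(=O)c2ccccc2Cl)sc2c1CCN(C(=S)Nc1ccccc1I)C2` is a group of 10 heavy atoms (7 carbon, 1 nitrogen, 1 sulfur, 1 iodine; one six-membered aromatic ring of carbon only) in place of a group of 10 heavy atoms (7 carbon, 1 nitrogen, 1 oxygen, 1 chlorine; one six-membered aromatic ring of carbon only), on an amine nitrogen in a ring. Within the data shown here, no measured step touches this kind of change: the one step available, from compound 1 to compound 2, concerns a different replacement and was itself small. Compound 3 is therefore expected to give 40000 nM, with a range from 15000 nM to 110000 nM. The expected step of a 1.1-fold lower number from compound 2 to compound 3 (0.05 log units; within the scatter) would sit within the scatter.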

Compound 3, half-maximal inhibitory concentration: 29000 nM
For compound 3 the middle estimate is 1.4-fold (0.14 log units) above the measured one, within the range that was stated.
By their numbers in this assay, from the lowest: compounds 1, 3 and 2 (each within the scatter of the next).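

Replacing (2-chlorophenyl)carbamoyl with the group carrying sulfur and iodine gives a 1.6-fold lower number from compound 2 to compound 3 (0.19 log units; within the scatter) in this assay and replacing the 2-chlorobenzyl group gives a 1.1-fold higher number from compound 1 to compound 3 (0.02 log units; within the scatter) on the same amine nitrogen in a ring. This amine nitrogen thus carries three different groups with all steps within the scatter, and the sulfur and iodine exchanges, made together, cannot be separated here. No measured evidence bears on this result. From the compounds shown here alone, whether sulfur or iodine alone would matter stays open. So does whether a carboxylic acid or a simple alkyl amine on this nitrogen would give a step beyond the scatter.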